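Trifluoromethyl Added to the Anilide Ring of Compound 2

The source may hold more compounds than are shown below. What is called first, only, known or untested is meant among the compounds shown, and "the series" means these compounds.

Compound 2 `O=C(COc1ccc(/C=C2\SC(=O)NC2=O)cc1)Nc1ccc(Cl)cc1` is one of three related compounds tested in a functional assay on Jurkat cells (Homo sapiens) for inhibition; on this read-out lower numbers stand for stronger inhibition of growth and higher numbers for weaker inhibition of growth. Compound 2 gives > 100000 nM, which is a limit of the assay rather than a number (the limit of > 100000 nM in this assay, at which 1 of the 3 values shown sits). Compound 1 `O=C(COc1ccc(/C=C2\SC(=O)NC2=O)cc1)Nc1ccc(F)cc1` gives 59900 nM, and compound 3 `O=C(COc1ccc(/C=C2\SC(=O)NC2=O)cc1)Nc1ccc(F)cc1F` gives 34600 nM. Going by the values given here, the steps of an at least 1.6-fold higher number from compound 1 to compound 2 (0.22 log units; that floor lies within the scatter) and a 1.7-fold lower number from compound 1 to compound 3 (0.24 log units; within the scatter) stay inside the scatter, while an at least 2.8-fold lower number from compound 2 to compound 3 (0.46 log units; beyond the scatter) is the only step that reaches beyond it. Compound 4 `O=C(COc1ccc(/C=C2\SC(=O)NC2=O)cc1)Nc1ccc(Cl)cc1C(F)(F)F` differs from compound 2 by trifluoromethyl in place of hydrogen on an aromatic carbon. Among the compounds with values here, no measured step exchanges hydrogen for trifluoromethyl, and the one addition to this ring, fluoro for hydrogen, moved the number little. The step from compound 2 is therefore expected to be small, a number no higher from compound 2 to compound 4 (the limit leaves the size open), with a fair chance of another limit. Compound 4 is estimated at 100000 nM, between 30000 nM and 300000 nM.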

Compound 4, concentration for 50% growth inhibition: 28900 nM
For compound 4 the middle estimate is 3.5-fold (0.54 log units) above the measured one; the measured number lies below the stated range.
By their numbers in this assay, from the lowest: compounds 4, 3 and 1 (each within the scatter of the next, the first and the last beyond it). At a limit, above all of these: compound 2.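

Trifluoromethyl on the aromatic carbon ortho to a large group and meta to a chloro group gives an at least 3.4-fold lower number from compound 2 to compound 4 (0.53 log units; beyond the scatter), so an addition to this ring can move the number beyond the scatter, towards stronger inhibition of growth. The earlier addition, fluoro for hydrogen, gave only a 1.7-fold lower number from compound 1 to compound 3 (0.24 log units; within the scatter). The full size of the new step stays unknown, since the value of compound 2 is a limit: the limit of > 100000 nM in this assay, at which 1 of the 4 values shown sits.

Going by these compounds, whether a methyl or methoxy group at this position would do the same remains open. So does whether trifluoromethyl would have this effect without the chloro group.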